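The source may hold more compounds than are shown below. What is called first, only, known or untested is meant among the compounds shown, and "the series" means these compounds.

Compound 1 `CCCn1c(=O)[nH]c2nc(-c3ccc(S(=O)(=O)N4CCN(c5ccc(Cl)cc5F)CC4)cc3)[nH]c2c1=O` gives > 1000 nM in an assay on CHO cells for displacement of a labelled ligand from adenosine receptor A3 (Homo sapiens), read by scintillation counting, with a stated time of 45 min, in the presence of a further agent that is not named here (on this read-out higher numbers stand for weaker inhibition and lower numbers for stronger inhibition), a limit.
Compound 2 `CCCn1c(=O)[nH]c2nc(-c3ccc(S(=O)(=O)N4CCN(c5cccc(Cl)c5)CC4)cc3)[nH]c2c1=O` gives 53.5 nM.
Compound 3 `CCCn1c(=O)[nH]c2nc(-c3ccc(S(=O)(=O)N4CCN(c5ccccc5Br)CC4)cc3)[nH]c2c1=O` gives > 1000 nM, also a limit.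

Compound 1 thus stands only at a limit of this assay, the same limit at which compound 3 sits (the limit of > 1000 nM in this assay, at which 2 of the 3 values shown sit); compound 2 alone yields a number. Compound 4 `CCCn1c(=O)[nH]c2nc(-c3ccc(S(=O)(=O)N4CCN(c5ccc(C)cc5)CC4)cc3)[nH]c2c1=O` differs from compound 1 in one place: 4-methylphenyl in place of 4-chloro-2-fluorophenyl on an amine nitrogen in a ring. For the measured compounds named here, two measured steps bear on this exchange of the aryl group on the ring amine: an at least 18-fold lower number from compound 1 to compound 2 (1.27 log units; beyond the scatter) and an at least 18-fold higher number from compound 2 to compound 3 (1.27 log units; beyond the scatter). With 4-chloro-2-fluorophenyl or 2-bromophenyl the number stays at the limit, while 3-chlorophenyl brings it well inside. A large fall in the number is expected from compound 1 to compound 4, an at least 8.3-fold lower number from compound 1 to compound 4 (0.92 log units; beyond the scatter). Compound 4 is therefore estimated at 120 nM, between 25 nM and 600 nM.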

Compound 4, inhibition constant: > 1000 nM
Compound 4 gave a limit, no number; the forecaster's own chance of this, stated with the estimate: 25%; middle value at least 8.3-fold (0.92 log units) from the limit.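

With 4-methylphenyl on the ring amine, the number does not come inside the range of this assay, so a methyl-bearing ring does no better here than the halogen-bearing rings of compound 1 and compound 3, and only 3-chlorophenyl gives a number: an at least 18-fold higher number from compound 2 to compound 4 (1.27 log units; beyond the scatter). The steps from compound 1 and from compound 3 to compound 4 cannot be read, as both ends are limits. Most of the series now sits at one limit: the limit of > 1000 nM in this assay, at which 3 of the 4 values shown sit.

From the compounds shown here alone, how far compound 1, compound 3 and compound 4 lie beyond that limit stays unknown. Also open, going by these compounds, is what plain phenyl, 3-methylphenyl or 3-methoxyphenyl would give, and so whether the chlorine itself matters.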